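The source may hold more compounds than are shown below. What is called first, only, known or untested is meant among the compounds shown, and "the series" means these compounds.

Compound 1 `Cc1nc(-c2ccc(F)cc2)ccc1C(=O)Nc1ccc2ncsc2c1`: 6.7
Compound 2 `N#Cc1ccc(C(=O)Nc2ccc3cccnc3c2)cn1`: < 6.7, a limit

In an in vitro functional assay on 1321-N1 cells for antagonist activity at transient receptor potential cation channel subfamily V member 1 (Homo sapiens), read by FLIPR and calcium flux (on this read-out higher numbers stand for higher potency (the scale is a negative logarithm) and lower numbers for lower potency), compound 1 gives 6.7. Compound 2 reaches only a limit of the assay, < 6.7, not a number. Compound 2 therefore stands at the limit of < 6.7 in this assay, at which 1 of the 2 values shown sits. Compound 3 `O=C(Nc1ccc2cccnc2c1)c1ccc(Cl)nc1` differs from compound 2 in one place: chloro in place of cyano on an aromatic carbon. Going by the values given here, no measured pair shows this change, so the step from compound 2 to compound 3 in this assay is expected to be small, with no clear direction. The expected step is a step that the limit leaves unreadable from compound 2 to compound 3. Compound 3 is estimated at 6.4, with a range from 5.5 to 7.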

Compound 3, negative logarithm of the antagonist equilibrium constant: < 6.7
Compound 3 gave a limit, no number; the forecaster's own chance of this, stated with the estimate: 60%; the middle value is on the limit's open side.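

Compound 2 and compound 3 both give only a limit, not a number, so no step can be read between them: the limit of < 6.7 in this assay, at which 2 of the 3 values shown sit.

Going by these compounds, whether chloro in place of cyano changes potency at all, and in which direction, stays open.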